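The compounds below may be only part of what the source reports. "The series", "measured", "known", "first", "only" and "open" are said of these compounds alone.

Measured so far:
compound 1 `Nc1scc(-c2ccccc2F)c1C(=O)c1ccc(Cl)cc1` — 87%
compound 2 `Nc1scc(-c2ccc(Cl)cc2)c1C(=O)c1ccc(Cl)cc1` — 50%

In a functional assay on CHO cells for agonist activity at adenosine receptor A1 (Homo sapiens), read by fluorescence and ERK phosphorylation, with stated times of 30 min and 1.5 h, tested at 10 uM (a lower number here means a weaker effect, a higher number a stronger effect of the compound at the concentration tested), compound 2 stands lowest of the two numbers; its nearest neighbour is compound 1, and the step of a number 37 percentage points lower from compound 1 to compound 2 (beyond the scatter) lies beyond the scatter. Compound 3 `Nc1scc(-c2ccc(I)cc2)c1C(=O)c1ccc(Cl)cc1` carries iodo in place of chloro on an aromatic carbon. Within the data shown here, the only measured step touching this ring, a number 37 percentage points lower from compound 1 to compound 2 (beyond the scatter), exchanged the whole group from 2-fluorophenyl to 4-chlorophenyl and does not cover a swap of one halogen for another. Among the measured compounds shown here, no measured step bears directly on this change. A step of no clear size beyond the scatter is therefore expected, no change at the digits printed from compound 2 to compound 3 (within the scatter), with a wide range. For compound 3 the estimate is 50%, from 30% to 75%.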

Compound 3, a percentage reported as activity, at one concentration (the size of the read-out at that concentration, not a potency): 61%
Beside the measured number, compound 3's estimate is 11 percentage points below it; measured number inside the range.
By their numbers in this assay, from the lowest: compound 2; then compound 3; then compound 1.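

In this assay, the step of a number 11 percentage points higher from compound 2 to compound 3 (beyond the scatter) shows that the read-out responds to the halogen alone, with iodo in place of chloro para to a large group and the rest of the structure unchanged. The step of a number 26 percentage points lower from compound 1 to compound 3 (beyond the scatter) shows that 4-iodophenyl still falls short of 2-fluorophenyl, so neither 4-halophenyl group shown matches compound 1. Nothing available explains the halogen effect.

From the compounds shown here alone, whether a 4-fluorophenyl, 4-methoxyphenyl or 4-aminophenyl group would fit this trend stays open. These single-concentration read-outs also leave potency open.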